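Quinoxaline for Dimethylpyrimidine on a Coumarin Sulfonamide

The source may hold more compounds than are shown below. What is called first, only, known or untested is meant among the compounds shown, and "the series" means these compounds.

Compound 1 `CC(=O)NS(=O)(=O)c1ccc(N/C=C\C(=O)c2cc3ccccc3oc2=O)cc1` carries an acetyl group on the sulfonamide nitrogen, but in a functional assay on T47D cells (Homo sapiens) for cytotoxicity, read by sulforhodamine B assay, with a stated time of 48 h (a higher number here means a weaker inhibitor, a lower number a stronger inhibitor), compound 1 gives no result reported. For the measured compounds named here, compound 2 `Cc1cc(C)nc(NS(=O)(=O)c2ccc(N/C=C\C(=O)c3cc4ccccc4oc3=O)cc2)n1` is therefore the only compound with a number: in this assay compound 2 gives 62200 nM, a weak inhibitor. Compound 3 `O=C(/C=C\Nc1ccc(S(=O)(=O)Nc2cnc3ccccc3n2)cc1)c1cc2ccccc2oc1=O` differs from it in one place, (quinoxalin-2-yl in place of 4,6-dimethylpyrimidin-2-yl on a sulfonamide nitrogen). Going by the values given here, no measured pair shows what this kind of exchange does, so the expected step from compound 2 to compound 3 is a 1.6-fold lower number from compound 2 to compound 3 (0.19 log units; within the scatter), a small gain that may not exceed the scatter. Compound 3 is estimated at 40000 nM, within 10000 nM to 150000 nM.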

Compound 3, half-maximal inhibitory concentration: 86900 nM
Compound 3: the middle estimate sits 2.2-fold (0.34 log units) below what was measured, and the stated range covers the measured number.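

Placing quinoxalin-2-yl in place of 4,6-dimethylpyrimidin-2-yl on a sulfonamide nitrogen gives a 1.4-fold higher number from compound 2 to compound 3 (0.15 log units; within the scatter) in this assay and so leaves the two compounds indistinguishable. This position therefore accepts a second aromatic ring, one of carbon only, with no change that can be read. Steps involving compound 1 cannot be read, so the acetyl group cannot be compared with either ring. From the compounds shown here alone, it remains open whether a sulfonamide nitrogen carrying a carboxylic acid or a simple amine-bearing chain would give a clearly different number. No measurement shown here accounts for this result.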